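This account rests on a few compounds, and the source may have more. Where it says the series, first, only, none or still open, it means among the compounds named here.

Series notes. Compound 1 `O=Cc1ccc(-c2cn3ccnc3c(-c3ccc4ncn(C5CCCCC5)c4c3)n2)cc1` and compound 2 `Fc1ccc(-c2cn3ccnc3c(-c3ccc4ncn(C5CCCCC5)c4c3)n2)cc1` share one core and differ only in the group carried on the pendant aryl ring. In a functional assay on RXF 393 cells (Homo sapiens) for inhibition, read by sulforhodamine B assay, with a stated time of 48 h, tested at 10 uM (on this read-out higher numbers stand for more inhibition at the one concentration tested (going by the name of the read-out) and lower numbers for less inhibition), compound 1 gives 25% and compound 2 gives 24.4%. Going by the values given here, the single measured step, a number 0.6 percentage points lower from compound 1 to compound 2 (within the scatter), is thus a flat one. Among the compounds with values here, of the two numbers, compound 2 holds the lower, with compound 1 as its only neighbour, but the gap between them sits within the scatter, so the two compounds cannot be told apart on this read-out.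

Compound 3 `c1cn2cc(-c3ccsc3)nc(-c3ccc4ncn(C5CCCCC5)c4c3)c2n1` keeps the same core and alters the same position once more: thiophen-3-yl in place of 4-fluorophenyl on an aromatic carbon. Within the data shown here, no measured step covers this particular exchange. Among the measured compounds shown here, the one step to hand, a number 0.6 percentage points lower from compound 1 to compound 2 (within the scatter), shows that changing what sits on that pendant ring left the read-out where it was, and nothing in the two numbers points to a move in either direction. The step from compound 2 to compound 3 is therefore expected to stay within the scatter, a number 0.6 percentage points higher from compound 2 to compound 3 (within the scatter). Compound 3 is accordingly estimated at 25% in this assay, with a range from 10% to 40%.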

Compound 3, a percentage reported as inhibition, at one concentration (the size of the read-out at that concentration, not a potency): 8.63%
Estimate against measurement, compound 3: 16.4 percentage points above; the measured number lies below the stated range.
By their numbers in this assay, from the lowest: compound 3; then compounds 2 and 1 (each within the scatter of the next).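

In this assay this position proves not to be indifferent to every change: thiophen-3-yl in place of 4-fluorophenyl gives a number 15.8 percentage points lower from compound 2 to compound 3 (beyond the scatter) on this read-out, and thiophen-3-yl in place of 4-formylphenyl gives a number 16.4 percentage points lower from compound 1 to compound 3 (beyond the scatter) in the same direction. Compound 1 and compound 2 both carry a six-membered aromatic ring of carbon only and stay within the scatter of each other, whereas compound 3, with a five-membered aromatic ring with 1 hetero atom, stands apart from both, so the flat first step holds only for the exchange made on the six-membered ring. No measured evidence on the origin of this difference is available here.

The exchange changes the ring size, brings in sulfur and removes the group carried on the pendant ring all at once, so a plain phenyl or a thiophen-3-yl bearing fluoro or formyl would be needed to separate these changes. From the compounds shown here alone, it also remains open whether an amine or a carboxylic acid on the pendant ring would lift the read-out above the level shared by compound 1 and compound 2.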